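The source may report more compounds than this note shows. Statements on the series, on what has been measured and on what is new or still open speak of the compounds shown alone.

Of the compounds shown here, two have been measured in a functional assay on A-375 cells (Homo sapiens) for inhibition, read by CCK-8 assay, with a stated time of 72 h; on this read-out higher numbers stand for weaker inhibition and lower numbers for stronger inhibition. Compound 1 `O=C(NO)c1ccc(CNC(=O)c2n[nH]cc2NC(=O)c2ccccc2Cl)cc1` gives 6420 nM. Compound 2 `Nc1ccccc1NC(=O)c1ccc(CNC(=O)c2n[nH]cc2NC(=O)c2ccccc2F)cc1` gives 2270 nM, the lower of the two numbers, and the gap between compound 2 and compound 1 is beyond the scatter. Compound 3 `COc1ccccc1C(=O)Nc1c[nH]nc1C(=O)NCc1ccc(C(=O)Nc2ccccc2N)cc1` has not yet been measured. It differs from compound 2 in one place: methoxy in place of fluoro on an aromatic carbon. Going by the values given here, no measured pair shows what this change does here, so the expected step, a 1.1-fold higher number from compound 2 to compound 3 (0.04 log units; within the scatter), is taken as small, with no direction beyond the scatter. Compound 3 is therefore estimated at 2500 nM, within a range from 900 nM to 7000 nM.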

Compound 3, half-maximal inhibitory concentration: 2660 nM
Estimate against measurement, compound 3: 1.1-fold (0.03 log units) below; the range from low to high includes it.
By their numbers in this assay, from the lowest: compounds 2 and 3 (each within the scatter of the next); then compound 1.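

In this assay, methoxy in place of fluoro, on an aromatic carbon ortho to a large group, gives a 1.2-fold higher number from compound 2 to compound 3 (0.07 log units; within the scatter) in this first pair to test the change. At this position, 2-fluorophenyl and 2-methoxyphenyl therefore cannot be told apart on this read-out, although methoxy, unlike fluoro, counts a hydrogen-bond acceptor. No measurement at hand offers an explanation. Still open, from the compounds shown here alone, is how an amine, a carboxylic acid or a longer chain such as ethoxy would fare at this position. Going by these compounds, whether the same swap would hold on the core of compound 1 is also open.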